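The source may hold more compounds than are shown below. What is called first, only, known or untested is meant among the compounds shown, and "the series" means these compounds.

Measured so far in a functional assay on HeLa cells (Homo sapiens) for antiproliferative activity, read by MTT assay, with a stated time of 48 h; a lower number here means a stronger inhibitor, a higher number a weaker inhibitor:
Compound 1 `O=[N+]([O-])c1cccc(-c2nn(-c3ccccc3)cc2C(Nc2nc3ccccc3s2)c2c(O)ccc3ccccc23)c1` gives 8220 nM.
Compound 2 `O=[N+]([O-])c1cccc(-c2nn(-c3ccccc3)cc2C(Nc2nc3ccc(Cl)cc3s2)c2c(O)ccc3ccccc23)c1` gives 15500 nM.
Compound 3 `Oc1ccc2ccccc2c1C(Nc1nc2ccc(Cl)cc2s1)c1cn(-c2ccccc2)nc1-c1cccc(Cl)c1` gives 18300 nM.

Compound 4 `Oc1ccc2ccccc2c1C(Nc1nc2ccc(Cl)cc2s1)c1cn(-c2ccccc2)nc1-c1ccccc1` has not yet been measured. It differs from compound 3 by hydrogen in place of chloro on an aromatic carbon. The same change has been made once before, where it gave a 1.9-fold lower number from compound 2 to compound 1 (0.28 log units; within the scatter). The two cores differ by chloro in place of nitro on an aromatic carbon. The surroundings of the change are not identical: in the measured pair the carbon sits in a six-membered aromatic ring of carbon only, part of a fused or bridged system of two rings, meta to a fused ring and para to a fused ring, whereas in compound 3 it sits in a six-membered aromatic ring of carbon only, meta to a large group, so this is the same kind of change rather than the same change. Beside a 1.9-fold lower number from compound 2 to compound 1 (0.28 log units; within the scatter), the expected step here is a 1.3-fold lower number from compound 3 to compound 4 (0.12 log units; within the scatter). This expectation rests on a 1.9-fold lower number from compound 2 to compound 1 (0.28 log units; within the scatter) lying within the scatter. For compound 4 the estimate in this assay is 14000 nM, with a likely range from 6000 nM to 35000 nM.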

Compound 4, half-maximal inhibitory concentration: 12500 nM
Estimate against measurement, compound 4: 1.1-fold (0.05 log units) above; the measured number falls inside the stated range.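

In this assay, hydrogen in place of chloro, turning 3-chlorophenyl into phenyl, gives a 1.5-fold lower number from compound 3 to compound 4 (0.17 log units; within the scatter), and hydrogen in place of nitro gives a 1.2-fold lower number from compound 2 to compound 4 (0.09 log units; within the scatter). The chloro-to-hydrogen change can be compared across two cores: the same change on two cores in this assay, a 1.9-fold lower number (0.28 log units; within the scatter) from compound 2 to compound 1 and a 1.5-fold lower number (0.17 log units; within the scatter) from compound 3 to compound 4, 1.3-fold (0.11 log units) apart, within the scatter of two such steps So the change carried over between these two cores without a detectable difference, but each step is itself within the scatter, so this does not show that the change has a real effect on either core, and two cores cannot establish a general rule.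

The compounds shown leave open whether a different group at this place, such as an amine or a carboxylic acid, would give a step beyond the scatter.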